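The compounds below may be only part of what the source reports. "The series", "measured", "known", "first", "only" and "open" are said of these compounds alone.

In an ADME assay on HEp-2 cells (Homo sapiens) for cytotoxicity, read by MTT assay, with a stated time of 72 h (on this read-out lower numbers stand for stronger inhibition and higher numbers for weaker inhibition), compound 1 (`COc1ccc(C2=C(c3cc(OC)c(OC)c(OC)c3)C(=O)C(O)C2)cc1NC(=O)c1ccccc1`) gives > 100 ug/mL as a limit of the assay. Compound 2 (`COc1ccc(C2=C(c3cc(OC)c(OC)c(OC)c3)C(=O)C(O)C2)cc1Cl`) gives < 1 ug/mL as a limit too. Compound 2 therefore has no exact number, and only its side of the limit is known. Compound 3 (`COc1ccc(C2=C(c3cc(OC)c(OC)c(OC)c3)C(=O)C(O)C2)cc1F`) differs from compound 2 through fluoro in place of chloro on an aromatic carbon with fluoro in place of chloro on an aromatic carbon, ortho to a methoxy group. Among the measured compounds shown here, the only measured step is an at least 100-fold lower number from compound 1 to compound 2 (2.00 log units; beyond the scatter) and it removes benzamido, so its large size does not carry over to an exchange of chloro for fluoro. For the measured compounds named here, no measured step covers that exchange. In this assay the expected result is a step that the limit leaves unreadable from compound 2 to compound 3 with no shift beyond the scatter anticipated in either direction. The estimated value for compound 3 is 0.7 ug/mL with an expected range from 0.1 ug/mL to 5 ug/mL on present evidence.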

Compound 3, half-maximal inhibitory concentration: < 1 ug/mL
Compound 3 was reported as a limit; the forecaster's own chance of this, stated with the estimate: 60%; the middle value lies beyond the limit too.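

In this assay compound 3 gives < 1 ug/mL, which is a limit of the assay and not a number. The large step is therefore not tied to chloro alone, because with fluoro at this place, ortho to a methoxy group, the series shows an at least 100-fold lower number from compound 1 to compound 3 (2.00 log units; beyond the scatter), so two different groups here sit on the low side of the limit while benzamido does not: the limit of < 1 ug/mL in this assay, at which 2 of the 3 values shown sit. The step between the chloro and fluoro compounds cannot be read, since both values are limits.

From the compounds shown here alone, how far past the limit compound 2 and compound 3 lie, and so whether chloro and fluoro differ at all, stays open. Also open, going by these compounds, is where between benzamido and these small groups the value turns, for instance with an amine or an acetamido group at the same place.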